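A few compounds are considered here, and "the series" means these few. Any claim that something is new, unique, unknown or untested is made for them only; others in the source may bear on it.

Compound 1 `COc1ccccc1NC1=C/C(=N/NC(N)=S)C(=O)N=C1Nc1ccccc1OC`: 13400 nM
Compound 2 `COc1ccc(NC2=C/C(=N/NC(N)=S)C(=O)N=C2Nc2ccc(OC)cc2)cc1`: 17800 nM
Compound 3 `CCOc1ccc(NC2=C/C(=N/NC(N)=S)C(=O)N=C2Nc2ccc(OCC)cc2)cc1`: 31000 nM

All three were tested in a functional assay on Bel-7402 cells (Homo sapiens) for antiproliferative activity, read by MTT assay, with a stated time of 72 h; a higher number here means a weaker inhibitor, a lower number a stronger inhibitor. Compound 1 gives the lowest of the three numbers; compound 2 sits within the usual scatter of it, so the two cannot be told apart, while compound 3 lies beyond the scatter and is the weaker inhibitor of the pair.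

Compound 4 `COc1ccccc1NC1=C/C(=N/N=C(\N)SCc2ccccc2)C(=O)N=C1Nc1ccccc1OC` is built from compound 1 by one change: a group of 11 heavy atoms (8 carbon, 2 nitrogen, 1 sulfur; one six-membered aromatic ring of carbon only) in place of a group of 4 heavy atoms (1 carbon, 2 nitrogen, 1 sulfur; no ring), on a double-bonded nitrogen. Within the data shown here, no measured pair in this set carries a change of this kind, so there is no step to lean on. Against the narrow spread among compounds 1, 2 and 3, a modest step toward a lower number seems the most likely outcome, but one that may well stay within the scatter. Compound 4 is therefore expected to give 9000 nM in this assay, with a range from 3000 nM to 27000 nM, a step estimated as a 1.5-fold lower number from compound 1 to compound 4 (0.17 log units; within the scatter).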

Compound 4, half-maximal inhibitory concentration: 13100 nM
Compound 4: middle estimate off by 1.5-fold (0.16 log units), on the low side; measured number inside the range.
By their numbers in this assay, from the lowest: compounds 4, 1, 2 and 3 (each within the scatter of the next, the first and the last beyond it).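

Putting a group of 11 heavy atoms, with its six-membered aromatic ring of carbon only, on a double-bonded nitrogen in place of a group of 4 heavy atoms gives, in this assay, a 1.0-fold lower number from compound 1 to compound 4 (0.01 log units; within the scatter), a step within the scatter. Compounds 1, 2 and 3 could not show this: the core of compound 1 carries this much larger group here with no readable difference in the number. Nothing measured here accounts for this result.

As far as these compounds go, whether a group carrying an amine or a carboxylic acid on that same nitrogen would also leave the number within the scatter stays open. So does whether the same exchange would behave alike on compound 2 or compound 3.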